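A Second Fluorine on the Carbamate Side Chain

The source may hold more compounds than are shown below. What is called first, only, known or untested is meant among the compounds shown, and "the series" means these compounds.

Three compounds share a core and differ in the aromatic ring attached through the carbamate. Compound 1 `CC(C)=CCC1Cc2c(OC(=O)Nc3ccc(F)cc3)cc(=O)n(CCCO)c2CC1(C)C` carries a 4-fluorophenyl group, and in a functional assay on PANC-1 cells (Homo sapiens) for inhibition, read by MTT assay, with a stated time of 24 h, tested at 10 uM (a lower number here means less inhibition, a higher number more inhibition at the concentration tested (going by the name of the read-out)), compound 1 gives 71.2%. Compound 2 `CC(C)=CCC1Cc2c(OC(=O)Nc3ccc(F)cc3F)cc(=O)n(CCCO)c2CC1(C)C` carries a 2,4-difluorophenyl group, and in this assay compound 2 gives 69.7%. The change between them is fluoro in place of hydrogen on an aromatic carbon, and it made a step of a number 1.5 percentage points lower from compound 1 to compound 2 (within the scatter).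

Compound 3 `CC(C)=CCC/C(C)=C/CC1Cc2c(OC(=O)Nc3ccccc3F)cc(=O)n(CCCO)c2CC1(C)C` has a longer side chain on the core and a 2-fluorophenyl group; in this assay compound 3 gives 71.6%. The difference between the core of compound 3 and the core of compound 1 is not broken down here.

Compound 4 `CC(C)=CCC/C(C)=C/CC1Cc2c(OC(=O)Nc3ccc(F)cc3F)cc(=O)n(CCCO)c2CC1(C)C` is not yet measured. It differs from compound 3 by fluoro in place of hydrogen on an aromatic carbon. This is the same kind of change as from compound 1 to compound 2, but not the same: in compound 2 the new fluoro sits ortho to a large group and meta to a fluoro group, while in compound 4 it sits meta to a fluoro group and para to a large group.

Because the earlier step was a number 1.5 percentage points lower from compound 1 to compound 2 (within the scatter), a similar small step is expected here, a number 1.6 percentage points lower from compound 3 to compound 4 (within the scatter). Compound 4 is therefore estimated to give 70% in this assay, expected between 60% and 80%.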

Compound 4, a percentage reported as inhibition, at one concentration (the size of the read-out at that concentration, not a potency): 33.7%
The estimate for compound 4 lay 36.3 percentage points above the measured number; measured number below the stated range.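

Adding a fluoro group to the aromatic ring does not carry over unchanged from one core to the other in this assay: the same change on two cores in this assay, a number 1.5 percentage points lower (within the scatter) from compound 1 to compound 2 and a number 37.9 percentage points lower (beyond the scatter) from compound 3 to compound 4, 36.4 percentage points apart, beyond the scatter of two such steps

Changing 2-fluorophenyl to 2,4-difluorophenyl on the longer side chain gives a number 37.9 percentage points lower from compound 3 to compound 4 (beyond the scatter), and adding a 3-methylbut-2-en-1-yl group to the side chain while keeping the 2,4-difluorophenyl group gives a number 36 percentage points lower from compound 2 to compound 4 (beyond the scatter), so the low number of compound 4 goes with the two features together rather than with either step taken alone. This does not show why the two features act together, and the core cannot be singled out as the only difference between the two fluoro steps, since the new fluoro in compound 4 sits meta to a fluoro group and para to a large group, which is not the same place as in compound 2.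

The compounds shown leave open whether the fall belongs to fluoro itself or would also follow from a chloro or methoxy group at that place on the longer side chain. They also leave open what a 4-fluorophenyl group would give on that longer side chain, which would separate the place of the fluoro from the core.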